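A few compounds are considered here, and "the series" means these few. Any claim that something is new, unique, unknown or untested is made for them only; others in the source may bear on it.

Measured compounds and their values:
- compound 1 `CC(CCc1cccc(OCc2ccc3ccccc3n2)c1)Cc1nnn[nH]1` gives 17 nM
- compound 2 `c1ccc2nc(COc3ccc(OCCCc4nnn[nH]4)cc3)ccc2c1` gives 69 nM
- compound 3 `CCCC(CCC(=O)O)Cc1ccc(OCc2ccc3ccccc3n2)cc1` gives 21 nM

All three were run in an assay on membranes from lung (Cavia porcellus) for binding affinity to cysteinyl leukotriene receptor (Homo sapiens); a higher number here means a weaker inhibitor, a lower number a stronger inhibitor. Compound 1 has the lowest number of the three, yet its gap to compound 3 lies within the scatter, so no order between compound 1 and compound 3 is claimed. For the measured compounds named here, only compound 2 sits clearly apart, with a number beyond the scatter above that of compound 1; no single-point step links compound 2 to either of the others, so the pair shows only what its two values show.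

The next compound is compound 4 `c1cc(CCCCc2nnn[nH]2)cc(OCc2ccc3ccccc3n2)c1`, which differs from compound 1 in one place: hydrogen in place of methyl on a saturated chain carbon bound to two saturated chain carbons. Going by the values given here, there is no measured pair that isolates a change of this kind, so no measured step can be quoted for it. The change is small in what it counts, and the expectation is a modest weakening in this assay, if any, with a step of a 1.8-fold higher number from compound 1 to compound 4 (0.25 log units; within the scatter) that may well stay within the scatter. For compound 4 the estimate is 30 nM, expected to fall between 10 nM and 90 nM.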

Compound 4, inhibition constant: 20 nM
Compound 4: middle estimate off by 1.5-fold (0.18 log units), on the high side, and the stated range covers the measured number.
By their numbers in this assay, from the lowest: compounds 1, 4 and 3 (each within the scatter of the next); then compound 2.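

For the compounds shown here, the first single-place step reads a 1.2-fold higher number from compound 1 to compound 4 (0.07 log units; within the scatter) in this assay, for hydrogen in place of methyl on a saturated chain carbon bound to two saturated chain carbons. The methyl at this carbon is therefore not required for a number of this size: with or without it, the two compounds cannot be told apart in this measurement. Nothing available bears on why this position tolerates the loss of the methyl.

Still open, from the compounds shown here alone, is whether a larger or heteroatom-bearing group on this carbon, such as ethyl, hydroxyl or an amine, would leave the number equally undisturbed. Also open, going by these compounds, is how a longer chain carrying the 1H-tetrazol-5-yl group would read against compound 4.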